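The source may report more compounds than this note shows. Statements on the series, on what has been measured and on what is new or still open speak of the compounds shown alone.

Measured compounds:
- compound 1, `COc1cc(C2=NN(C(C)=O)C(c3c(Cl)cccc3Cl)O2)cc(OC)c1OC`, -2.2%
- compound 2, `COc1cc(C(=O)N/N=C/c2cccc(C(F)(F)F)c2)cc(OC)c1OC`, 79.8%

In a functional assay on PC-3 cells (Homo sapiens) for antiproliferative activity, read by MTT assay, tested at 5 uM (on this read-out lower numbers stand for a weaker effect and higher numbers for a stronger effect at the one concentration tested), compound 1 stands at the bottom of the two numbers: compound 2 gives a value far higher, a gap beyond the scatter. Compound 3, `COc1cc(C2=NN(C(C)=O)C(c3ccc(F)cc3)O2)cc(OC)c1OC`, has not yet been measured. It differs from compound 1 in one place: 4-fluorophenyl in place of 2,6-dichlorophenyl on a saturated ring carbon. For the measured compounds named here, no measured pair shows what this kind of swap does, so the expected step of a number 7.2 percentage points higher from compound 1 to compound 3 (within the scatter) is small and may not reach beyond the scatter in either direction. Compound 3 is therefore estimated at 5%, with a likely range from -12% to 30%.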

Compound 3, a percentage reported as inhibition, at one concentration (the size of the read-out at that concentration, not a potency): 0.1%
For compound 3 the middle estimate is 4.9 percentage points above the measured one, within the range that was stated.
By their numbers in this assay, from the lowest: compounds 1 and 3 (each within the scatter of the next); then compound 2.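

In this assay, putting 4-fluorophenyl in place of 2,6-dichlorophenyl on the saturated ring carbon gives a number 2.3 percentage points higher from compound 1 to compound 3 (within the scatter) and so does not separate the two groups. At this position, then, this change of ring substituents leaves the read-out unchanged within the usual scatter. No data here bear on why the two compounds read alike.

Still open, from the compounds shown here alone, is whether an amine or a carboxylic acid on this phenyl ring would give a different reading. Also open, going by these compounds, is whether a longer chain in place of the acetyl group would do so.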